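Shifting the attachment point of the benzodioxin group

The source may hold more compounds than are shown below. What is called first, only, known or untested is meant among the compounds shown, and "the series" means these compounds.

Compound 1 `COc1ccc(C2=NN(C(=O)C3COc4ccccc4O3)C(c3cccc(F)c3)C2)cc1` stands second highest of the three numbers measured in a functional assay on WM 266-4 cells (Homo sapiens) for inhibition, read by MTT assay, with a stated time of 24 h (a lower number here means a stronger inhibitor of growth, a higher number a weaker inhibitor of growth), where compound 1 gives 6720 nM. Compound 2 `COc1ccc(C2=NN(C(=O)C3COc4ccccc4O3)C(c3ccc(F)cc3)C2)cc1` gives 6190 nM and compound 3 `O=C(C1COc2ccccc2O1)N1N=C(c2ccc(Br)cc2)CC1c1cccc(F)c1` gives 7810 nM; a 1.1-fold lower number from compound 1 to compound 2 (0.04 log units; within the scatter) and a 1.2-fold higher number from compound 1 to compound 3 (0.07 log units; within the scatter) both lie within the scatter. Compound 4 `COc1ccc(C2=NN(C(=O)c3ccc4c(c3)OCCO4)C(c3cccc(F)c3)C2)cc1` has the same atoms as compound 1, joined differently: 2,3-dihydro-1,4-benzodioxin-6-yl in place of 2,3-dihydro-1,4-benzodioxin-2-yl on a carbonyl carbon. Neither measured step touches the carbonyl carbon, so none of them bears directly on this change; all that is known is that the three numbers sit close together. On that basis no step beyond the scatter is expected in this assay, with wider uncertainty than usual. For compound 4 the estimate is 7000 nM, within a range from 2500 nM to 20000 nM, which means an expected 1.0-fold higher number from compound 1 to compound 4 (0.02 log units; within the scatter).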

Compound 4, concentration for 50% growth inhibition: 930 nM
For compound 4 the middle estimate is 7.5-fold (0.88 log units) above the measured one; the measured number lies below the stated range.
By their numbers in this assay, from the lowest: compound 4; then compounds 2, 1 and 3 (each within the scatter of the next).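

In this assay, 2,3-dihydro-1,4-benzodioxin-6-yl in place of 2,3-dihydro-1,4-benzodioxin-2-yl on the carbonyl carbon gives a 7.2-fold lower number from compound 1 to compound 4 (0.86 log units; beyond the scatter). The earlier steps shown here, at the fluorophenyl group and at the methoxy group, stayed within the scatter, whereas this one shows that the way this group is joined to the carbonyl carbon counts even with the same atoms. Nothing available here accounts for the size of this step. On these data alone, it remains open whether the lower number persists alongside the 4-fluorophenyl or bromo changes. As far as these compounds go, whether an amine or a carboxylic acid on the 2,3-dihydro-1,4-benzodioxin-6-yl group would keep it is also open.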